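Benzyl to Cyclohexyl on the Amine Nitrogen

A few compounds are considered here, and "the series" means these few. Any claim that something is new, unique, unknown or untested is made for them only; others in the source may bear on it.

Compound 2 `Cc1ccc(S(=O)(=O)/N=C(/CCNC2=CC(=O)c3ccccc3C2=O)NCc2ccccc2)cc1` has been tested in a functional assay on HeLa cells (Homo sapiens) for cytotoxicity, read by MTT assay, with a stated time of 48 h (a higher number here means a weaker inhibitor, a lower number a stronger inhibitor), where compound 2 gives 3980 nM, the lower of the two numbers in hand. The other measured compound is compound 1 `COc1ccc(N/C(CCNC2=CC(=O)c3ccccc3C2=O)=N\S(=O)(=O)c2ccc(C)cc2)c(OC)c1`; in this assay compound 1 gives 67600 nM, and the step of a 17-fold lower number from compound 1 to compound 2 (1.23 log units; beyond the scatter) is large. Compound 3 `Cc1ccc(S(=O)(=O)/N=C(/CCNC2=CC(=O)c3ccccc3C2=O)NC2CCCCC2)cc1` is not yet measured; it differs from compound 2 by cyclohexyl in place of benzyl on an amine nitrogen. Among the compounds with values here, no measured step covers this change: the one known step replaces one group on that nitrogen with a different one and does not directly bear on it. Only a modest step is therefore expected, a 1.3-fold higher number from compound 2 to compound 3 (0.10 log units; within the scatter), close to the scatter. Compound 3 is estimated at 5000 nM, ranging from 1500 nM to 16000 nM.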

Compound 3, half-maximal inhibitory concentration: 9770 nM
Compound 3: the middle estimate sits 2.0-fold (0.29 log units) below what was measured; the measured number falls inside the stated range.
By their numbers in this assay, from the lowest: compound 2; then compound 3; then compound 1.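

Replacing benzyl with cyclohexyl on the amine nitrogen gives a 2.5-fold higher number from compound 2 to compound 3 (0.39 log units; beyond the scatter) in this assay and shows that an aromatic ring in this group is not needed for activity in the low range seen here, although benzyl keeps the lower number. Cyclohexyl also gives a 6.9-fold lower number from compound 1 to compound 3 (0.84 log units; beyond the scatter) so both groups give lower numbers than 2,4-dimethoxyphenyl. No measurement here explains these differences. As far as these compounds go, whether a plain phenyl, a phenylethyl chain or a smaller group such as methyl on this nitrogen would give a lower number remains open.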